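A halogenated aryl swap on a weak piperazine sulfonamide

The source may report more compounds than this note shows. Statements on the series, on what has been measured and on what is new or still open speak of the compounds shown alone.

The study concerns compound 1 `CCCn1c(=O)[nH]c2nc(-c3ccc(S(=O)(=O)N4CCN(c5ccc(F)cc5)CC4)cc3)[nH]c2c1=O` and its relative compound 3 `CCCn1c(=O)[nH]c2nc(-c3ccc(S(=O)(=O)N4CCN(c5cccc(Cl)c5)CC4)cc3)[nH]c2c1=O`, which share the same core. In an assay on CHO cells for displacement of a labelled ligand from adenosine receptor A1 (Homo sapiens), read by scintillation counting, with a stated time of 90 min, in the presence of a further agent that is not named here (on this read-out lower numbers stand for stronger inhibition and higher numbers for weaker inhibition), compound 1 gives > 1000 nM, a limit of the assay rather than a number. Compound 1 therefore stands only at the lower edge of what this assay resolves, the point described by the limit of > 1000 nM in this assay, at which 1 of the 2 values shown sits. Within the data shown here, one measured step touches the same position: compound 2 `CCCn1c(=O)[nH]c2nc(-c3ccc(S(=O)(=O)N4CCN(Cc5cccc(C)c5)CC4)cc3)[nH]c2c1=O`, which in this assay gives 795 nM, differs from compound 1 by a 3-methylbenzyl group, and the change an at least 1.2-fold lower number from compound 1 to compound 2 (0.09 log units; that floor lies within the scatter) has a floor inside the usual scatter. Compound 3 arises from compound 1 through (3-chlorophenyl in place of 4-fluorophenyl on an amine nitrogen in a ring). Among the measured compounds shown here, no measured step tests a chlorine-bearing aryl at this position, so the only guide is that compound 1 is already at a limit and that the single neighbouring change did not move beyond the scatter. He therefore expects compound 3 to remain weak, with a step that the limit leaves unreadable from compound 1 to compound 3 that may itself end at a limit. His estimate for compound 3 in this assay is 1500 nM, ranging from 400 nM to 6000 nM.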

Compound 3, inhibition constant: > 1000 nM
Compound 3 gave a limit, no number; the forecaster's own chance of this, stated with the estimate: 55%; the middle value is on the limit's open side.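

In this assay, placing 3-chlorophenyl in place of 4-fluorophenyl on an amine nitrogen in a ring leaves compound 3 at the same limit of the assay as compound 1: the limit of > 1000 nM in this assay, at which 2 of the 3 values shown sit.

The step between these two compounds cannot be read, so the result does not rank the two aryl groups; it shows only that a second halogen-bearing phenyl group at this position also yields a limit rather than a number. Among these compounds, the one step that can be read is an at least 1.2-fold higher number from compound 2 to compound 3 (0.09 log units; that floor lies within the scatter), and its floor lies within the usual scatter, so the data do not set 3-methylbenzyl apart from 3-chlorophenyl here.

Going by these compounds, how far compound 1 and compound 3 actually lie beyond the limit remains open, as does whether either group would separate from the other on a read-out with a wider range. Also open, on these data alone, is whether a different group on this nitrogen, such as an unsubstituted benzyl, a 3-chlorobenzyl, or a short chain ending in an amine, would give a value clearly apart from compound 2.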